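The source may report more compounds than this note shows. Statements on the series, on what has been measured and on what is new or still open speak of the compounds shown alone.

Measured in a functional assay on MCF7 cells (Homo sapiens) for cytotoxicity, with a stated time of 48 h; a lower number here means a stronger inhibitor, a higher number a weaker inhibitor:
- compound 1 `COc1cccc(/C=C/C(=O)c2c(OC)cc(OC)cc2OC)c1`: 9400 nM
- compound 2 `COc1cc(OC)c(C(=O)/C=C/c2ccc(Cl)cc2)c(OC)c1`: 7500 nM

In this assay, among the measured compounds shown here, compound 1 gives 9400 nM, and the only comparison available is a 1.3-fold lower number from compound 1 to compound 2 (0.10 log units; within the scatter). Neither compound therefore stands apart from the other on these numbers.

Compound 3 `COc1cccc(/C=C/C(=O)c2c(O)cc(OC)cc2OC)c1` keeps the core of compound 1 and has hydrogen in place of methyl on an oxygen on an aromatic ring, methoxy to hydroxy (hydrogen in place of methyl on an oxygen on an aromatic ring).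

For the measured compounds named here, no measured step covers this change. Going by the values given here, the single step available, a 1.3-fold lower number from compound 1 to compound 2 (0.10 log units; within the scatter), concerns a different group and bears on it only loosely, so the data give no direction. The expected step is a 1.2-fold lower number from compound 1 to compound 3 (0.07 log units; within the scatter), which means no change beyond the scatter is expected, with wide uncertainty. For compound 3 the estimated value is 8000 nM, with an expected range from 2500 nM to 25000 nM.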

Compound 3, half-maximal inhibitory concentration: 10300 nM
For compound 3 the middle estimate is 1.3-fold (0.11 log units) below the measured one; low and high end bracket the measured number.
By their numbers in this assay, from the lowest: compounds 2, 1 and 3 (each within the scatter of the next).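

In this assay the change from methoxy to hydroxy, hydrogen in place of methyl on an oxygen on an aromatic ring, gives a 1.1-fold higher number from compound 1 to compound 3 (0.04 log units; within the scatter) and so leaves the number within the scatter at this position. Among the compounds shown here, the earlier step concerned only the 3-methoxyphenyl group, so this is the first sign that a second place on the core of compound 1 can be changed without a step beyond the scatter. No data at hand bear on the reason for this result.

Still open, as far as these compounds go, is whether a larger group on the same oxygen, such as a longer chain, or an amine in place of the hydroxy would separate from compound 1. Also open, from the compounds shown here alone, is whether the hydroxy and the 4-chlorophenyl group together would read differently from either change alone.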